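Anilino trifluoromethyl step on the unbenzylated core

This account rests on a few compounds, and the source may have more. Where it says the series, first, only, none or still open, it means among the compounds named here.

Compound 1 `COc1ccc(Cn2nc(-c3ccccc3)c3cc(C(=N)Nc4cccc(C(F)(F)F)c4)nc(NC4CCCCC4)c32)cc1` in a functional assay on MDA-MB-231 cells (Homo sapiens) for cytotoxicity, read by MTT assay, with a stated time of 72 h (a higher number here means a weaker inhibitor, a lower number a stronger inhibitor), gives only a limit of the assay, > 50000 nM.
Compound 2 `N=C(Nc1ccccc1)c1cc2c(-c3ccccc3)n[nH]c2c(NC2CCCCC2)n1` in this assay gives 1710 nM.
Compound 3 `COc1ccc(Cn2nc(-c3ccccc3)c3cc(C(=N)Nc4ccccc4)nc(NC4CCCCC4)c32)cc1` in this assay gives 3400 nM.

Compound 2 holds the lowest of the two numbers; the nearest is compound 3, with a 2.0-fold higher number from compound 2 to compound 3 (0.30 log units; within the scatter), so these two do not separate. Compound 1 provides no number, only the limit.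

Compound 4 `N=C(Nc1cccc(C(F)(F)F)c1)c1cc2c(-c3ccccc3)n[nH]c2c(NC2CCCCC2)n1` differs from compound 2 in one place: trifluoromethyl in place of hydrogen on an aromatic carbon. Going by the values given here, the only measured step that bears on this change is the reverse one within the 4-methoxybenzyl-bearing pair, an at least 14-fold lower number from compound 1 to compound 3 (1.16 log units; beyond the scatter). Its true size is known only as a bound, because compound 1 sits at the limit of > 50000 nM in this assay, at which 1 of the 3 values shown sits. Nothing shows whether the same change behaves alike on the core of compound 2, which carries hydrogen on the aromatic nitrogen rather than 4-methoxybenzyl, so the transfer is an assumption.

Reading the bounded step backwards, the trifluoromethyl is expected to raise the number markedly, with an estimated step of an 18-fold higher number from compound 2 to compound 4 (1.24 log units; beyond the scatter). The estimate for compound 4 in this assay is 30000 nM, within a range of 8000 nM to 120000 nM. Given where compound 1 lies, a fair chance remains that compound 4 again returns only a limit.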

Compound 4, half-maximal inhibitory concentration: 24600 nM
Compound 4: middle estimate off by 1.2-fold (0.09 log units), on the high side; the range from low to high includes it.
By their numbers in this assay, from the lowest: compounds 2 and 3 (each within the scatter of the next); then compound 4. At a limit, above all of these: compound 1.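

On the core with hydrogen on the aromatic nitrogen, the change from anilino to (3-(trifluoromethyl)phenyl)amino now has a measured size in this assay, a 14-fold higher number from compound 2 to compound 4 (1.16 log units; beyond the scatter), where the earlier pair gave only a bound. The higher number with trifluoromethyl therefore appears on both cores, with and without 4-methoxybenzyl, though how closely the two steps agree cannot be settled: the same change on two cores in this assay, an at least 14-fold lower number (1.16 log units; beyond the scatter) from compound 1 to compound 3 and a 14-fold lower number (1.16 log units; beyond the scatter) from compound 4 to compound 2; the limit leaves it open whether they differ. Hydrogen in place of 4-methoxybenzyl on the aromatic nitrogen, in the trifluoromethyl pair, gives an at least 2.0-fold lower number from compound 1 to compound 4 (0.30 log units; that floor lies within the scatter), which is only a floor, so this step cannot yet be set against the same change in the unsubstituted anilino pair: the same change on two cores in this assay, a 2.0-fold higher number (0.30 log units; within the scatter) from compound 2 to compound 3 and an at least 2.0-fold higher number (0.30 log units; that floor lies within the scatter) from compound 4 to compound 1; the limit leaves it open whether they differ.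

Going by these compounds, the true size of both steps involving compound 1 remains open, since that compound gives only a limit. The series here offers just hydrogen and trifluoromethyl at this place on the anilino ring, so a methyl, a methoxy or an amine on the same aromatic carbon would show whether the rise in the number is particular to trifluoromethyl or follows any group there.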